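Adding a Methoxy Group to a Melatonin Receptor Ligand

This account rests on a few compounds, and the source may have more. Where it says the series, first, only, none or still open, it means among the compounds named here.

Compound 2, `CCC(=O)NCC1CCc2ccccc2N1`: 242 nM
Compound 1, `CCNC(=O)NCC1CCc2c(cccc2OC)N1`: "not determined" (no result reported)

Going by the values given here, in a functional assay on CHO cells with melatonin receptor type 1A (Homo sapiens) as the target, read by GTPgammaS binding, with a stated time of 1 h (a lower number here means that less compound is needed, a higher number that more compound is needed for the effect), compound 2 gives 242 nM, which is the only number available, since compound 1 has no reported result. Compound 3, `CCC(=O)NCC1CCc2c(cccc2OC)N1`, differs from compound 2 by methoxy in place of hydrogen on an aromatic carbon. Among the compounds with values here, no measured pair shows this change, so its size can only be expected: a step well beyond the usual scatter, towards less compound being needed. The expected step is a 16-fold lower number from compound 2 to compound 3 (1.21 log units; beyond the scatter). Compound 3 is therefore estimated at 15 nM, with a likely range from 2 nM to 100 nM.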

Compound 3, half-maximal effective concentration: 906 nM
Compound 3: the middle estimate sits 60-fold (1.78 log units) below what was measured; measured number outside the range, above it.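

In this assay, methoxy in place of hydrogen on this aromatic carbon, ortho to a fused ring and meta to a fused ring, gives a 3.7-fold higher number from compound 2 to compound 3 (0.57 log units; beyond the scatter), so more compound is needed for the effect. Going by these compounds alone, this is the first measured reading of the change, as compound 1 carries the same methoxy but has no reported result. Nothing available explains the direction of this step. Whether the higher number is specific to methoxy remains open, as the compounds shown include no hydroxyl, fluorine or ethoxy at this position. As far as these compounds go, how methoxy would behave on another carbon of the aromatic ring also remains open.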